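Compound 4: a new phenyl group against an assay limit

The source may report more compounds than this note shows. Statements on the series, on what has been measured and on what is new or still open speak of the compounds shown alone.

Compound 1 `COc1ccccc1-n1cc(COC(=O)/C(C)=C/CC/C(C)=C/CC/C(C)=C/CC[C@@H]2[C@@]3(C)CCC(=O)C(C)(C)[C@H]3CC[C@@]2(C)O)nn1`, compound 2 `C/C(=C\CC/C(C)=C/CC[C@@H]1[C@@]2(C)CCC(=O)C(C)(C)[C@H]2CC[C@@]1(C)O)CC/C=C(\C)C(=O)OCc1cn(-c2cccc(F)c2)nn1` and compound 3 `C/C(=C\CC/C(C)=C/CC[C@@H]1[C@@]2(C)CCC(=O)C(C)(C)[C@H]2CC[C@@]1(C)O)CC/C=C(\C)C(=O)OCc1cn(-c2ccc(Cl)cc2)nn1` share one core and differ only in the substituted phenyl group on an aromatic nitrogen. In a functional assay on DU-145 cells (Homo sapiens) for antiproliferative activity, read by MTT assay, with a stated time of 48 h (a lower number here means a stronger inhibitor, a higher number a weaker inhibitor), compound 3 gives > 150000 nM as a limit, not a number. Compound 1 gives > 150000 nM as a limit too. Compound 2 likewise gives > 150000 nM as a limit. All three therefore stand together at the limit of > 150000 nM in this assay, at which 3 of the 3 values shown sit, and none can be ranked. Compound 4 `C/C(=C\CC/C(C)=C/CC[C@@H]1[C@@]2(C)CCC(=O)C(C)(C)[C@H]2CC[C@@]1(C)O)CC/C=C(\C)C(=O)OCc1cn(-c2cccc(O)c2)nn1` carries 3-hydroxyphenyl in place of 4-chlorophenyl on an aromatic nitrogen, a change counted as 3-hydroxyphenyl in place of 4-chlorophenyl on an aromatic nitrogen and not yet tested. The closest evidence is a step that the two limits leave unreadable from compound 1 to compound 2, a step that the two limits leave unreadable from compound 1 to compound 3 and a step that the two limits leave unreadable from compound 2 to compound 3, each a swap of one substituted phenyl for another, and none has a readable size. They therefore point in no direction, and no clear gain is expected. The expected step is a step that the limit leaves unreadable from compound 3 to compound 4 and it remains an estimate. Compound 4 is estimated at 170000 nM, with an expected range from 60000 nM to 400000 nM and another limit the likeliest report.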

Compound 4, half-maximal inhibitory concentration: 28400 nM
For compound 4 the middle estimate is 6.0-fold (0.78 log units) above the measured one, outside the stated range (below it).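

In this assay, compound 4 is the first of these compounds whose substituted phenyl group on the aromatic nitrogen gives a number rather than a limit, with an at least 5.2-fold lower number from compound 3 to compound 4 (0.72 log units; beyond the scatter) and an at least 5.2-fold lower number from compound 1 to compound 4 (0.72 log units; beyond the scatter). The sharpest comparison is a single swap of hydroxy for fluoro on an aromatic carbon, which gives an at least 5.2-fold lower number from compound 2 to compound 4 (0.72 log units; beyond the scatter), and all three sizes are minimum sizes. This shows that a change in this phenyl group can move the result, although the other three compounds remain at the same limit: the limit of > 150000 nM in this assay, at which 3 of the 4 values shown sit.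

The compounds shown leave open whether the hydroxy group's place on the phenyl ring matters, which 2-hydroxyphenyl and 4-hydroxyphenyl groups would test. They also leave open whether 3-methoxyphenyl, or an amine or a carboxylic acid in place of the hydroxy, would keep this result.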